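Inversion at the amino-bearing carbon of the hydroxypropyl amide

This account rests on a few compounds, and the source may have more. Where it says the series, first, only, none or still open, it means among the compounds named here.

Measured so far in an assay on isolated protein for inhibition of sphingosine kinase 1 (Homo sapiens), read by mobility shift assay; a lower number here means a stronger inhibitor, a higher number a weaker inhibitor:
- compound 1 `CCCCCCCCc1ccc(NC(=O)C(N)C(C)(C)O)cc1`, giving 2100 nM
- compound 2 `CCCCCCCCc1ccc(NC(=O)[C@H](N)[C@H](C)O)cc1`, giving 2100 nM

Compound 2 stands level with compound 1 at the digits shown; the step of no change at the digits printed from compound 1 to compound 2 (within the scatter) is within the scatter, so swapping the side chain on the carbonyl carbon left the read-out unchanged.

Compound 3 `CCCCCCCCc1ccc(NC(=O)[C@@H](N)[C@H](C)O)cc1` is next. Its difference from compound 2 is the two compounds have the same atoms and bonds and differ only in configuration as drawn: 1 of 2 stereo elements differ; a stereocentre at a saturated chain carbon is drawn R in compound 2 and S in compound 3; nothing leaves and nothing enters.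

Among the compounds with values here, no measured step isolates a change of configuration. Within the data shown here, the single step on record, no change at the digits printed from compound 1 to compound 2 (within the scatter), alters the side chain itself, and compound 1 is drawn without configuration at either centre, so the pair compound 1 and compound 2 only shows that the two side chains read the same. Nothing therefore points to a step in either direction for compound 3, and the expectation is no change beyond the scatter, with a wider band of uncertainty than a repeat measurement would carry.

For compound 3 the expected step is no change at the digits printed from compound 2 to compound 3 (within the scatter) in this assay.

Compound 3 is estimated at 2100 nM, with a range from 600 nM to 7000 nM.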

Compound 3, half-maximal inhibitory concentration: 1100 nM
For compound 3 the middle estimate is 1.9-fold (0.28 log units) above the measured one; the measured number falls inside the stated range.
By their numbers in this assay, from the lowest: compounds 3, 1 and 2 (each within the scatter of the next).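

The series now holds a step that isolates configuration at a saturated chain carbon, and the reading in this assay is a 1.9-fold lower number from compound 2 to compound 3 (0.28 log units; within the scatter) for a change confined to the drawing of one centre: the fact that compounds 2 and 3 differ only in the configuration as drawn. Within this assay the two drawings of that stereocentre are not separated, so this pair supports no preference for R or S at this position. The side-chain comparison now reaches the new isomer as well, with a 1.9-fold lower number from compound 1 to compound 3 (0.28 log units; within the scatter) for 1-amino-2-hydroxypropyl in place of 1-amino-2-hydroxy-2-methylpropyl on a carbonyl carbon, which leaves all three compounds together whichever side chain or drawing is taken.

Going by these compounds, compounds 2 and 3 differ at only one of the two stereo elements, so the effect of changing the other one, alone or together with the first, remains open. Also open, on these data alone, is whether a carboxylic acid in place of the hydroxyl on the side chain, a methylated amine in place of the free amine, or a longer chain on the shared core would move the number beyond the scatter.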